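Carbamate aryl variation in a PANC-1 growth inhibition series

The source may hold more compounds than are shown below. What is called first, only, known or untested is meant among the compounds shown, and "the series" means these compounds.

Measured so far:
- compound 1 `CC(C)=CCC1Cc2c(O)cc(=O)n(CCCO)c2CC1(C)C`: 25.6%
- compound 2 `CC(C)=CCC1Cc2c(OC(=O)Nc3cccc(F)c3)cc(=O)n(CCCO)c2CC1(C)C`: 66.1%

Both numbers come from a functional assay on PANC-1 cells (Homo sapiens) for inhibition, read by MTT assay, with a stated time of 24 h, tested at 10 uM; a lower number here means less inhibition, a higher number more inhibition at the concentration tested (going by the name of the read-out). Going by the values given here, compound 2 stands highest of the two measured compounds; the nearest is compound 1, and the one step recorded, a number 40.5 percentage points higher from compound 1 to compound 2 (beyond the scatter), is beyond the scatter, so the carbamate carries most of the inhibition seen so far.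

Compound 3 `CC(C)=CCC1Cc2c(OC(=O)Nc3ccc(F)c(Cl)c3)cc(=O)n(CCCO)c2CC1(C)C` has not been measured. Its change from compound 2 is 3-chloro-4-fluorophenyl in place of 3-fluorophenyl on an amide-type nitrogen. Among the compounds with values here, no measured step touches the aryl part of the carbamate; the only recorded step concerns the presence of the whole (3-fluorophenyl)carbamoyl group, not its substitution. That step therefore sets the level, not the direction, for compound 3. With nothing to push it either way, compound 3 is expected to stay near compound 2, the expected step being a number 0.1 percentage points lower from compound 2 to compound 3 (within the scatter), within the scatter. The estimate for compound 3 in this assay is 66%, with a range from 46% to 84%.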

Compound 3, a percentage reported as inhibition, at one concentration (the size of the read-out at that concentration, not a potency): 79.8%
Estimate against measurement, compound 3: 13.8 percentage points below; measured number inside the range.
By their numbers in this assay, from the lowest: compound 1; then compound 2; then compound 3.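

In this assay, the aryl group on the amide-type nitrogen is not a silent part of the carbamate: 3-chloro-4-fluorophenyl in place of 3-fluorophenyl gives a number 13.7 percentage points higher from compound 2 to compound 3 (beyond the scatter), so the read-out responds to substitution on this ring and not only to the presence of the carbamoyl group. Measured against the free hydroxyl, the (3-chloro-4-fluorophenyl)carbamoyl group gives a number 54.2 percentage points higher from compound 1 to compound 3 (beyond the scatter), and compound 3 is the highest of the three, with its steps to both others beyond the scatter. No measured information explains this gain.

On these data alone, how 3-chlorophenyl or 4-fluorophenyl would compare on the same nitrogen remains open, so the contributions of the chlorine and the fluorine cannot be separated. Also open, as far as these compounds go, is whether a methoxy-substituted phenyl, a carboxylic acid on the phenyl ring or a cyclohexyl group would hold this level.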